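The compounds below may be only part of what the source reports. "The series", "measured", "known", "first", "only" and "open" are said of these compounds alone.

Series notes. Compound 1 `O=C(NNc1ccccc1Cl)c1ccc(NS(=O)(=O)c2cnc(O)nc2O)cc1` and compound 2 `O=C(NNc1cccc(Cl)c1)c1ccc(NS(=O)(=O)c2cnc(O)nc2O)cc1` share one core; compound 3 `O=C(NNc1ccccc1Cl)c1cccc(NS(=O)(=O)c2cnc(O)nc2O)c1` and the as yet unmeasured compound 4 `O=C(NNc1cccc(Cl)c1)c1cccc(NS(=O)(=O)c2cnc(O)nc2O)c1` share another. The difference between the two cores is not broken down here. In a functional assay on MDA-MB-231 cells (Homo sapiens) for antiproliferative activity, read by MTT assay, with a stated time of 24 h (on this read-out lower numbers stand for stronger inhibition and higher numbers for weaker inhibition), compound 1 gives 4010 nM, and compound 2 gives 17400 nM. The change between them is 3-chlorophenyl in place of 2-chlorophenyl on an amine nitrogen and it produced a 4.3-fold higher number from compound 1 to compound 2 (0.64 log units; beyond the scatter). In this assay compound 3 gives 2090 nM, the lowest number of the three measured, though its gap to compound 1 lies within the scatter and its gap to compound 2 beyond it.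

Compound 4 differs from compound 3 by 3-chlorophenyl in place of 2-chlorophenyl on an amine nitrogen, the same change as from compound 1 to compound 2, at the same place. With one prior example only, the expectation rests on that step: a loss of comparable size, a 4.1-fold higher number from compound 3 to compound 4 (0.61 log units; beyond the scatter), is expected from compound 3 to compound 4 in this assay. On that basis compound 4 is estimated at 8500 nM in this assay, likely between 3000 nM and 25000 nM.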

Compound 4, half-maximal inhibitory concentration: 7760 nM
For compound 4 the middle estimate is 1.1-fold (0.04 log units) above the measured one; the measured number falls inside the stated range.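

In this assay the replacement of 2-chlorophenyl by 3-chlorophenyl on an amine nitrogen gives a 3.7-fold higher number from compound 3 to compound 4 (0.57 log units; beyond the scatter) and so repeats the loss already seen on the other core. Set beside the earlier step, the change carries from one core to the other with no difference in size that can be told from the scatter: the same change on two cores in this assay, a 4.3-fold higher number (0.64 log units; beyond the scatter) from compound 1 to compound 2 and a 3.7-fold higher number (0.57 log units; beyond the scatter) from compound 3 to compound 4, 1.2-fold (0.07 log units) apart, within the scatter of two such steps.

This rests on two cores and a single pair of chlorophenyl groups, so it supports transfer of this one change between these two cores and does not show that it would hold on any further core or for any other substituent; it also gives no reason for the loss.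

The compounds shown leave open whether an unsubstituted phenyl, a methoxyphenyl or a cyanophenyl on the same amine nitrogen would fall in line with the two chlorophenyl groups. Also open, going by these compounds, is whether a bromine in place of the chlorine would give a step of similar size on both cores.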